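Shifting methyl positions on the benzoyl ring of compound 3

The source may hold more compounds than are shown below. What is called first, only, known or untested is meant among the compounds shown, and "the series" means these compounds.

Compound 3 `Cc1ccc(C)c(C(=O)c2c(OCC(=O)Nc3ccc(S(N)(=O)=O)cc3C)ccc3cc(Br)ccc23)c1` shows the lowest number among three measured compounds in an ADME assay on C8166 cells (Homo sapiens) for cytotoxicity, read by colorimetric assay and MTT assay (on this read-out lower numbers stand for higher toxicity in this test and higher numbers for lower toxicity in this test), where compound 3 gives 14000 nM. Compound 1 `Cc1cc(S(N)(=O)=O)ccc1NC(=O)COc1ccc2cc(Br)ccc2c1C(=O)c1cccc(F)c1` gives 31000 nM and compound 2 `Cc1cc(C)cc(C(=O)c2c(OCC(=O)Nc3ccc(S(N)(=O)=O)cc3C)ccc3cc(Br)ccc23)c1` gives 24500 nM. The change to compound 4 `Cc1ccc(C(=O)c2c(OCC(=O)Nc3ccc(S(N)(=O)=O)cc3C)ccc3cc(Br)ccc23)cc1C` is 3,4-dimethylphenyl in place of 2,5-dimethylphenyl on a carbonyl carbon. For the measured compounds named here, the nearest precedent is a 1.8-fold lower number from compound 2 to compound 3 (0.24 log units; within the scatter), and the wider step a 2.2-fold lower number from compound 1 to compound 3 (0.35 log units; beyond the scatter) also replaced the same ring. Both steps were small, and the dimethyl isomers measured so far lie close together, so compound 4 is expected to remain near compound 3, with an expected step of a 1.2-fold higher number from compound 3 to compound 4 (0.08 log units; within the scatter). Compound 4 is therefore estimated at 17000 nM, with a likely range from 8500 nM to 35000 nM.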

Compound 4, half-maximal cytotoxic concentration: 85200 nM
Estimate against measurement, compound 4: 5.0-fold (0.70 log units) below, outside the stated range (above it).
By their numbers in this assay, from the lowest: compounds 3, 2 and 1 (each within the scatter of the next, the first and the last beyond it); then compound 4.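

In this assay, the group on the carbonyl carbon proves sensitive to where the two methyl groups sit, since the isomeric 3,4-dimethylphenyl gives a 6.1-fold higher number from compound 3 to compound 4 (0.78 log units; beyond the scatter) and a 3.5-fold higher number from compound 2 to compound 4 (0.54 log units; beyond the scatter), each larger than any step among the first three compounds. The same group also separates from 3-fluorophenyl, with a 2.7-fold higher number from compound 1 to compound 4 (0.44 log units; beyond the scatter), so compound 4 has the highest number of the four, beyond the scatter of every other. Nothing measured here bears on why these isomers differ.

On these data alone, it remains open whether a single methyl group at either of these ring positions would behave the same way. The compounds shown also leave open how a 3,4-dichlorophenyl or 3,4-dimethoxyphenyl group would read at this carbonyl carbon.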